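A Formyl Group Added to a Second Core

A few compounds are considered here, and "the series" means these few. Any claim that something is new, unique, unknown or untested is made for them only; others in the source may bear on it.

compound 1 `c1ccn(Nc2ccncc2)c1`: > 20 mg/kg
compound 2 `CN(c1ccncc1)n1cccc1`: > 20 mg/kg
compound 3 `O=Cc1cccn1Nc1ccncc1`: > 20 mg/kg

In a functional assay on the whole organism with Mus musculus as the target (a lower number here means that less compound is needed, a higher number that more compound is needed for the effect), compound 1 gives > 20 mg/kg, which is a limit of the assay and not a number. Compound 2 differs from compound 1 by methyl in place of hydrogen on a nitrogen on an aromatic ring. In this assay compound 2 gives > 20 mg/kg, again only a limit. Compound 3 carries formyl in place of hydrogen on an aromatic carbon. In this assay compound 3 gives > 20 mg/kg, also a limit. The step that the two limits leave unreadable from compound 1 to compound 3 is therefore unreadable because of the limit of > 20 mg/kg in this assay, at which 3 of the 3 values shown sit.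

Compound 4 `CN(c1ccncc1)n1ccc(C=O)c1` is not yet measured. It carries formyl in place of hydrogen on an aromatic carbon. This is the same kind of change as in compound 3, but the place differs: in compound 3 the formyl sits next to the ring nitrogen and next to the ring atom that bears a group of 7 heavy atoms, whereas in compound 4 it sits two ring bonds from the ring nitrogen and two ring bonds from the ring atom that bears a group of 8 heavy atoms.

Compound 4 is expected to show a step that the limit leaves unreadable from compound 2 to compound 4, an estimate resting on a step that the two limits leave unreadable from compound 1 to compound 3 being unreadable and on (the limit of > 20 mg/kg in this assay, at which 3 of the 3 values shown sit). Compound 4 is accordingly estimated at 40 mg/kg, most likely between 15 mg/kg and 120 mg/kg, with a limit again the most probable outcome.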

Compound 4, dose for half-maximal effect: > 20 mg/kg
Compound 4: a limit, no number (the forecaster's own chance of this, stated with the estimate: 85%); the middle value lies beyond the limit too.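

Going by these compounds alone, compound 2 and compound 4 both give only a limit and not a number, so no step between them can be read. The compounds shown leave open what dose any of them needs in this assay, and whether formyl changes it.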